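The source may hold more compounds than are shown below. What is called first, only, known or untested is meant among the compounds shown, and "the series" means these compounds.

Measured so far in a physicochemical assay for solubility, in phosphate buffer, measured as kinetic solubility, at pH 7.4, tested at 250 uM; on this read-out higher numbers stand for higher solubility and lower numbers for lower solubility:

- compound 1 `COCCCCNc1ccc(C(=O)O)cc1S(=O)(=O)N(C)C`: 247000 nM
- compound 2 `O=C(O)c1ccc(NCCCCCCCC(F)(F)F)c(S(=O)(=O)N2CCCC2)c1`: 66000 nM

Of these two numbers, compound 2 at 66000 nM holds the lower one, and the gap to compound 1 at 247000 nM lies beyond the usual scatter of repeated measurements. The two compounds differ in more than one place, so the gap cannot be tied to any single change.

The next compound, compound 3 `O=C(O)c1ccc(NCCCCCCCC(F)(F)F)c(S(=O)(=O)NC2CCOCC2)c1`, departs from compound 2 in one place only: (oxan-4-yl)amino in place of pyrrolidin-1-yl on a sulfonyl sulfur. In words, (oxan-4-yl)amino stands in place of pyrrolidin-1-yl on a sulfonyl sulfur, and the rest of the structure stays the same. For the measured compounds named here, no measured pair in this small set shows a change in one place, so the expectation rests on little evidence. A modest upward move is expected, and it may not clear the scatter. The estimated change is a 1.4-fold higher number from compound 2 to compound 3 (0.16 log units; within the scatter). In this assay the estimate for compound 3 is 95000 nM, with an expected range from 35000 nM to 220000 nM.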

Compound 3, solubility: 244000 nM
Estimate against measurement, compound 3: 2.6-fold (0.41 log units) below; measured number above the stated range.
By their numbers in this assay, from the lowest: compound 2; then compounds 3 and 1 (each within the scatter of the next).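

For the compounds shown here, for the first time in this assay, a gap can be tied to a single change: (oxan-4-yl)amino in place of pyrrolidin-1-yl gives a 3.7-fold higher number from compound 2 to compound 3 (0.57 log units; beyond the scatter), a step that lies beyond the scatter. With the rest of the structure unchanged, this shows that the group on a sulfonyl sulfur whose other neighbour is an aromatic carbon is not a silent place in this read-out, and that swapping one saturated ring for another there can shift the number. No measurement at hand offers an explanation for the move.

The entering group differs from the one that leaves in several ways at once, with a six-membered ring, a ring oxygen and a hydrogen on the sulfonamide nitrogen arriving together, so the compounds shown leave open which of these parts goes with the higher number. From the compounds shown here alone, a cyclohexylamino group or a morpholine ring on the same sulfonyl sulfur would pull those parts apart, and whether the same change carries over to a different chain on the shared core also remains open.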